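Compound 3 to compound 4: a new carbonyl substituent

A few compounds are considered here, and "the series" means these few. Any claim that something is new, unique, unknown or untested is made for them only; others in the source may bear on it.

In a functional assay on NCI-H1650 cells (Homo sapiens) for cytotoxicity, read by MTT assay, with a stated time of 72 h (a higher number here means a weaker inhibitor, a lower number a stronger inhibitor), compound 1 `COc1cc(/C=C2\CNC/C(=C\c3cc(OC)c(OC)c(OC)c3)C2=O)cc(OC)c1OC`, with hydrogen on an amine nitrogen in a ring, gives 4200 nM. Compound 2 `CCN1C/C(=C\c2cc(OC)c(OC)c(OC)c2)C(=O)/C(=C/c2cc(OC)c(OC)c(OC)c2)C1`, with ethyl there, gives 8200 nM, and the first step reads a 2.0-fold higher number from compound 1 to compound 2 (0.29 log units; within the scatter). Compound 3 `COc1cc(/C=C2\CN(C(=O)C(C)C)C/C(=C\c3cc(OC)c(OC)c(OC)c3)C2=O)cc(OC)c1OC`, with isopropylcarbonyl there, gives 10800 nM. Compound 3 therefore stands level with compound 2 within the scatter, a 1.3-fold higher number from compound 2 to compound 3 (0.12 log units; within the scatter), but apart from compound 1, a 2.6-fold higher number from compound 1 to compound 3 (0.41 log units; beyond the scatter).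

Compound 4 `COc1cc(/C=C2\CN(C(=O)c3ccccc3F)C/C(=C\c3cc(OC)c(OC)c(OC)c3)C2=O)cc(OC)c1OC` has 2-fluorophenyl in place of isopropyl on a carbonyl carbon. Within the data shown here, no measured step changes the group on this carbonyl carbon, so the evidence is indirect. The steps to compound 3 are small, one modest and one within the scatter, and they span only hydrogen, ethyl and isopropylcarbonyl. No step beyond the scatter is therefore expected, in either direction, though the range stays wide. The expected change is a 1.2-fold lower number from compound 3 to compound 4 (0.08 log units; within the scatter). Compound 4 is estimated at 9000 nM, with an expected range of 3500 nM to 22000 nM.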

Compound 4, half-maximal inhibitory concentration: 1900 nM
Beside the measured number, compound 4's estimate is 4.7-fold (0.68 log units) above it; measured number below the stated range.
By their numbers in this assay, from the lowest: compound 4; then compounds 1, 2 and 3 (each within the scatter of the next, the first and the last beyond it).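

In this assay the group on the carbonyl carbon proves able to move the number well beyond the scatter (in 2-fluorophenyl for isopropyl, a 5.7-fold lower number from compound 3 to compound 4 (0.75 log units; beyond the scatter)), so an amide-type nitrogen does not by itself set the level. Acylation of the ring nitrogen no longer means a loss against hydrogen: compound 3 stood above compound 1, whereas (2-fluorophenyl)carbonyl gives the lowest number of the four, both against hydrogen (a 2.2-fold lower number from compound 1 to compound 4 (0.34 log units; beyond the scatter)) and against ethyl (a 4.3-fold lower number from compound 2 to compound 4 (0.64 log units; beyond the scatter)). Nothing measured here accounts for this gain.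

On these data alone, a plain phenyl on this carbonyl carbon would separate the share of the fluorine from that of the aromatic ring, and that comparison stays open. Also open, as far as these compounds go, is how an amine or a longer chain on this carbonyl carbon would read.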